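The compounds below may be only part of what the source reports. "The series", "measured", "known", "first", "only" and "open" are said of these compounds alone.

Compound 1 `O=C(CCCC1CCN(S(=O)(=O)CCc2ccccc2)CC1)c1ncco1` and compound 2 `CC(C)S(=O)(=O)N1CCC(CCCC(=O)c2ncco2)CC1` share a core and differ only at the sulfonyl sulfur. In an assay on isolated protein for inhibition of Fatty-acid amide hydrolase 1 (Homo sapiens) (on this read-out lower numbers stand for stronger inhibition and higher numbers for weaker inhibition), compound 1 gives 6 nM, while compound 2 gives 140 nM, the highest of the two numbers; the step of a 23-fold higher number from compound 1 to compound 2 (1.37 log units; beyond the scatter) is large. Compound 3 `O=C(CCCC1CCN(Cc2cccc(Br)c2)CC1)c1ncco1` carries 3-bromobenzyl in place of isopropylsulfonyl on an amine nitrogen in a ring. Among the compounds with values here, only that one step bears on this change, and it shows that a group with an aromatic ring on the ring nitrogen went with a far lower number. A lower number is therefore expected for compound 3, and the expected step is a 3.5-fold lower number from compound 2 to compound 3 (0.54 log units; beyond the scatter). Within the data shown here, the uncertainty is wide: no measured compound lacks the sulfonyl. Compound 3 is estimated at 40 nM, between 8 nM and 200 nM.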

Compound 3, half-maximal inhibitory concentration: 10 nM
Beside the measured number, compound 3's estimate is 4.0-fold (0.60 log units) above it; the measured number falls inside the stated range.
By their numbers in this assay, from the lowest: compounds 1 and 3 (each within the scatter of the next); then compound 2.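

Compound 3 shows that the sulfonyl is not required for a low number at this ring nitrogen: replacing isopropylsulfonyl with 3-bromobenzyl gives a 14-fold lower number from compound 2 to compound 3 (1.15 log units; beyond the scatter). Compound 1 and compound 3 stand within the scatter of each other, and both carry an aromatic ring, which compound 2 lacks. No evidence at hand accounts for this difference.

Open, from the compounds shown here alone, is what a plain benzyl without the bromine would give at this nitrogen. Also open, going by these compounds, is whether an isopropyl group attached directly to the nitrogen, without the sulfonyl, would give a low number.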